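Swapping the phenyl of compound 3 for a substituted ring

The source may report more compounds than this note shows. Statements on the series, on what has been measured and on what is new or still open speak of the compounds shown alone.

Measured in a functional assay on MCF7 cells (Homo sapiens) for antiproliferative activity, read by CellTiter-Glo, with a stated time of 5 days; a higher number here means a weaker inhibitor, a lower number a stronger inhibitor:
- compound 1 `CC/C(=C(/c1ccc(/C=C/C(=O)O)cc1)c1ccc2scnc2c1)c1ccccc1`: 90 nM
- compound 2 `CC/C(=C(/c1ccc(/C=C/C(=O)O)cc1)c1ccc2sncc2c1)c1ccccc1`: > 500 nM, which is a limit of the assay and not a number
- compound 3 `O=C(O)/C=C/c1ccc(/C(=C(\c2ccccc2)C2CCC2)c2ccc3scnc3c2)cc1`: 16 nM

Of the two true numbers in this assay, the lower belongs to compound 3 at 16 nM, so it is the stronger inhibitor of that pair. The next compound, compound 4 `N#Cc1ccc(/C(=C(\c2ccc(/C=C/C(=O)O)cc2)c2ccc3scnc3c2)C2CCC2)c(Cl)c1`, keeps everything in compound 3 except one group. It has 2-chloro-4-cyanophenyl in place of phenyl on a double-bonded chain carbon bound to a double-bonded chain carbon and a saturated ring carbon.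

Among the compounds with values here, no measured step replaces this phenyl, so the evidence is indirect. Swapping ethyl for cyclobutyl on that same carbon gave a 5.6-fold lower number from compound 1 to compound 3 (0.75 log units; beyond the scatter). A change in a different group gave an at least 5.5-fold higher number from compound 1 to compound 2 (0.74 log units; beyond the scatter). Both steps show that a single change in this series can move the number beyond the scatter, but neither sets a direction for the new ring. A small move toward a lower number is therefore expected, with a move the other way still possible. The estimated step is a 2.0-fold lower number from compound 3 to compound 4 (0.30 log units; within the scatter). The estimate for compound 4 is 8 nM, with an expected range from 2 nM to 35 nM.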

Compound 4, half-maximal inhibitory concentration: 1.4 nM
Estimate against measurement, compound 4: 5.7-fold (0.76 log units) above; the measured number lies below the stated range.
By their numbers in this assay, from the lowest: compound 4; then compound 3; then compound 1. At a limit, above all of these: compound 2.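

In this assay, the ring on the double-bonded chain carbon bound to a double-bonded chain carbon and a saturated ring carbon turns out to be a site of real sensitivity: 2-chloro-4-cyanophenyl in place of phenyl gives an 11-fold lower number from compound 3 to compound 4 (1.06 log units; beyond the scatter). Within the data shown here, the earlier steps changed other groups, so this is the first direct sign that the phenyl can be replaced by a larger substituted ring without losing activity, and that doing so here lowers the number beyond the scatter. Nothing measured among these compounds says why the number fell.

From the compounds shown here alone, the chlorine and the nitrile enter together, so their separate contributions remain open, and a phenyl carrying only one of them would be needed to tell them apart. Also open, going by these compounds, are how other groups on this ring, such as a methoxy, an amine or a carboxylic acid, would behave, and whether the same ring would lower the number with ethyl in place of cyclobutyl.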